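A few compounds are considered here, and "the series" means these few. Any claim that something is new, unique, unknown or untested is made for them only; others in the source may bear on it.

Compound 1 `O=C(CCCCCCNC(=O)C(O)(O)C(F)(F)F)Nc1nc2ccccc2s1` was tested in a functional assay on HCT-116 cells (Homo sapiens) for inhibition, read by colorimetric assay, with a stated time of 3 days (a lower number here means a stronger inhibitor, a higher number a weaker inhibitor), where compound 1 gives 2370 nM. Among the three compounds measured so far this is the second highest number. Compound 2 `COc1ccc2sc(NC(=O)CCCCCCNC(=O)C(O)(O)C(F)(F)F)nc2c1`, with methoxy in place of hydrogen on an aromatic carbon, gives 2180 nM, and the step is a 1.1-fold lower number from compound 1 to compound 2 (0.04 log units; within the scatter). Compound 3 `O=C(CCCCCCNC(=O)C(O)(O)C(F)(F)F)Nc1nc2ccc(F)cc2s1`, with fluoro in place of hydrogen on an aromatic carbon, gives 6470 nM, and here the step is a 2.7-fold higher number from compound 1 to compound 3 (0.44 log units; beyond the scatter).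

The next compound, compound 4 `O=C(CCCCCCNC(=O)C(O)(O)C(F)(F)F)Nc1nc2ccccc2o1`, alters the shared core itself: 1,3-benzoxazol-2-yl in place of 1,3-benzothiazol-2-yl on an amide-type nitrogen. Neither measured step bears directly on this change, because a 1.1-fold lower number from compound 1 to compound 2 (0.04 log units; within the scatter) and a 2.7-fold higher number from compound 1 to compound 3 (0.44 log units; beyond the scatter) both replace a hydrogen on an aromatic carbon while the core of compound 1 is kept. For the measured compounds named here, what the two steps do show is that small changes to this series have so far produced either no movement beyond the scatter or a modest rise in the number; nothing so far points to a sharp fall. The expected step is therefore small to modest, more likely toward a higher number than a lower one, and written as a 1.5-fold higher number from compound 1 to compound 4 (0.17 log units; within the scatter). Compound 4 is accordingly estimated to give 3500 nM, with a range from 1200 nM to 10000 nM.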

Compound 4, half-maximal inhibitory concentration: 3450 nM
The estimate for compound 4 lay 1.0-fold (0.01 log units) above the measured number; the range from low to high includes it.
By their numbers in this assay, from the lowest: compounds 2, 1, 4 and 3 (each within the scatter of the next, the first and the last beyond it).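

In this assay, for the compounds shown here, the earlier steps each replaced a hydrogen on an aromatic carbon and kept the core of compound 1, whereas this step is the first to alter the core itself, and it gives a 1.5-fold higher number from compound 1 to compound 4 (0.16 log units; within the scatter) for 1,3-benzoxazol-2-yl in place of 1,3-benzothiazol-2-yl on an amide-type nitrogen. The exchange swaps one sulfur for one oxygen, leaves the counts of heavy atoms, rings, hydrogen-bond donors and hydrogen-bond acceptors unchanged, and in this single pair does not move the number beyond the scatter. Nothing available here explains this outcome.

Going by these compounds, this is one pair of compounds, so it remains open whether the same exchange would also stay within the scatter with methoxy or fluoro on the aromatic ring, as in the compounds that carry the 1,3-benzothiazol-2-yl group. Also open, on these data alone, is how the number would respond to an amine or a carboxylic acid on the shared core, or to a shorter or longer chain linking the core to the far amide.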